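The source may hold more compounds than are shown below. What is called first, only, known or untested is meant among the compounds shown, and "the series" means these compounds.

Measured so far:
compound 1, `c1ccc2[nH]c(CN3CCN(c4ccncc4)CC3)nc2c1`, > 10000 nM
compound 2, `Clc1cccc(N2CCN(Cc3nc4ccccc4[nH]3)CC2)c1`, 9.6 nM; 9.6 nM (2 entries)

In an assay on isolated protein for binding affinity to D(4) dopamine receptor (Homo sapiens) (on this read-out higher numbers stand for weaker inhibition and lower numbers for stronger inhibition), compound 1 reaches only the assay limit, > 10000 nM, and no number is known for it. In this assay compound 2 gives 9.6 nM; 9.6 nM (2 entries). Within the data shown here, these are the only two values available, and no step between compounds differing in one place is recorded for the series.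

Compound 3, `COc1cccc(N2CCN(Cc3nc4ccccc4[nH]3)CC2)c1`, is not yet measured. It differs from compound 1 by 3-methoxyphenyl in place of pyridin-4-yl on an amine nitrogen in a ring; in words, 3-methoxyphenyl in place of pyridin-4-yl on an amine nitrogen in a ring. Since compound 1 sits at the limit of > 10000 nM in this assay, at which 1 of the 2 values shown sits, the step from it cannot be computed from a number. A gain in binding is expected, well beyond the usual scatter, with the expected step being an at least 330-fold lower number from compound 1 to compound 3 (2.52 log units; beyond the scatter). For compound 3 in this assay an inhibition constant of 30 nM is estimated, expected to fall between 5 nM and 200 nM.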

Compound 3, inhibition constant: 26.5 nM
Compound 3: the middle estimate sits 1.1-fold (0.05 log units) above what was measured; the range from low to high includes it.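

In this assay, 3-methoxyphenyl in place of pyridin-4-yl on an amine nitrogen in a ring gives an at least 370-fold lower number from compound 1 to compound 3 (2.57 log units; beyond the scatter). This step is only a bound, because compound 1 stands at an assay limit: the limit of > 10000 nM in this assay, at which 1 of the 3 values shown sits.

Compound 3 gives 26.5 nM and compound 2 gives 9.6 nM; 9.6 nM (2 entries), so both compounds with a six-membered aromatic ring of carbon only at this place show measurable binding, while compound 1, with pyridin-4-yl, goes against them; the leaving and entering groups have the same hydrogen-bond acceptor count, so that count does not separate them.

The compounds shown leave open whether the step follows from losing the ring nitrogen of pyridin-4-yl or from gaining the methoxy group. Unsubstituted phenyl at the same place would separate these two changes, and the response to an amine or a carboxylic acid on the phenyl ring remains unknown.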